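A few compounds are considered here, and "the series" means these few. Any claim that something is new, unique, unknown or untested is made for them only; others in the source may bear on it.

Working notes on the sulfonyl quinoxaline series. Compound 1 `O=S(=O)(c1ccccc1)c1nc2ccccc2nc1Nc1ccc(Cl)cc1` gives 2000 nM in a functional assay on HCT-116 cells (Homo sapiens) for cytotoxicity, read by MTT assay, with a stated time of 72 h; on this read-out higher numbers stand for weaker inhibition and lower numbers for stronger inhibition. Compound 2 `O=S(=O)(c1ccccc1)c1nc2ccccc2nc1Nc1ccc(C(F)(F)F)cc1` carries the change trifluoromethyl in place of chloro on an aromatic carbon and gives 2090 nM in this assay; the step of a 1.0-fold higher number from compound 1 to compound 2 (0.02 log units; within the scatter). Compound 3 `O=S(=O)(c1ccc(Br)cc1)c1nc2ccccc2nc1Nc1ccc(Cl)cc1` differs from compound 1 in its core by bromo in place of hydrogen on an aromatic carbon; in this assay compound 3 gives 10600 nM, the step of a 5.3-fold higher number from compound 1 to compound 3 (0.72 log units; beyond the scatter). Compound 4 `O=S(=O)(c1ccc(Br)cc1)c1nc2ccccc2nc1Nc1ccc(C(F)(F)F)cc1` is not yet measured; it differs from compound 3 by trifluoromethyl in place of chloro on an aromatic carbon, the same change as from compound 1 to compound 2, made on the core of compound 3. Because a 1.0-fold higher number from compound 1 to compound 2 (0.02 log units; within the scatter) lies within the scatter, the step from compound 3 to compound 4 is expected to be small as well, a 4.8-fold lower number from compound 3 to compound 4 (0.68 log units; beyond the scatter). For compound 4 the expected value in this assay is 2200 nM, with a range of 1000 nM to 5000 nM.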

Compound 4, half-maximal inhibitory concentration: 2610 nM
Compound 4: middle estimate off by 1.2-fold (0.07 log units), on the low side, within the range that was stated.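

Trifluoromethyl in place of chloro gives a 4.1-fold lower number from compound 3 to compound 4 (0.61 log units; beyond the scatter) on the core of compound 3, so in this assay this change does not carry over unchanged from the core of compound 1: the same change on two cores in this assay, a 1.0-fold higher number (0.02 log units; within the scatter) from compound 1 to compound 2 and a 4.1-fold lower number (0.61 log units; beyond the scatter) from compound 3 to compound 4, 4.2-fold (0.63 log units) apart, beyond the scatter of two such steps. Bromo in place of hydrogen gives a 1.2-fold higher number from compound 2 to compound 4 (0.10 log units; within the scatter), and this step also differs from its counterpart on the other core: the same change on two cores in this assay, a 5.3-fold higher number (0.72 log units; beyond the scatter) from compound 1 to compound 3 and a 1.2-fold higher number (0.10 log units; within the scatter) from compound 2 to compound 4, 4.2-fold (0.63 log units) apart, beyond the scatter of two such steps. Both comparisons rest on the same set of compounds, so they form a single observation that the two changes are not independent, and they show neither the reason nor whether this extends to other groups.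

From the compounds shown here alone, it remains open whether an amine or a carboxylic acid in place of chloro or trifluoromethyl would follow compound 4 or compound 2. The same question stands for methoxy in place of bromo.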